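This account rests on a few compounds, and the source may have more. Where it says the series, first, only, none or still open, it means among the compounds named here.

Measured so far in a functional assay on CRL2813 cells (Homo sapiens) for cytotoxicity, read by sulforhodamine B assay, with a stated time of 5 days; on this read-out higher numbers stand for weaker inhibition and lower numbers for stronger inhibition: compound 1 `O=C(Nc1ccc(I)cc1)N[C@H]1CC[C@H](Oc2ccc(F)cc2)CC1` gives 10200 nM. Compound 2 `O=C(Nc1ccc(F)cc1)N[C@H]1CC[C@H](Oc2ccc(F)cc2)CC1` gives 20000 nM. Compound 3 `CSc1ccc(NC(=O)N[C@H]2CC[C@H](Oc3ccc(F)cc3)CC2)cc1` reaches only the limit of the assay, > 20000 nM.

Compound 3 thus stands at the limit of > 20000 nM in this assay, at which 1 of the 3 values shown sits, with no number of its own; the step of an at least 1.9-fold higher number from compound 1 to compound 3 (0.29 log units; that floor lies within the scatter) and the step of a number no lower from compound 2 to compound 3 (the limit leaves the size open) are both open-ended, and a 2.0-fold higher number from compound 1 to compound 2 (0.29 log units; within the scatter) lies within the scatter. Compound 4 `O=C(Nc1ccccc1Cl)N[C@H]1CC[C@H](Oc2ccc(F)cc2)CC1` differs from compound 3 by 2-chlorophenyl in place of 4-(methylsulfanyl)phenyl on an amide-type nitrogen. The measured steps that bear on it each swap one substituent on the ring attached to the amide-type nitrogen, and none of them shows a change beyond the scatter. In this assay the step expected from compound 3 to compound 4 is an at least 1.3-fold lower number from compound 3 to compound 4 (0.12 log units; that floor lies within the scatter), nothing beyond the scatter. Compound 4 is therefore estimated at 15000 nM, between 5000 nM and 40000 nM, with a fair chance that only a limit is reported again.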

Compound 4, half-maximal inhibitory concentration: 9100 nM
Compound 4: middle estimate off by 1.6-fold (0.22 log units), on the high side; the range from low to high includes it.
By their numbers in this assay, from the lowest: compounds 4, 1 and 2 (each within the scatter of the next, the first and the last beyond it).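

In this assay the group on the amide-type nitrogen now gives steps beyond the scatter: a 2.2-fold lower number from compound 2 to compound 4 (0.34 log units; beyond the scatter), and an at least 2.1-fold lower number from compound 3 to compound 4 (0.34 log units; beyond the scatter). Against that, a 1.1-fold lower number from compound 1 to compound 4 (0.05 log units; within the scatter), so 2-chlorophenyl and 4-iodophenyl cannot be told apart here. Compound 3 remains a limit of the assay, which makes its step a floor: the limit of > 20000 nM in this assay, at which 1 of the 4 values shown sits.

Open, as far as these compounds go, is whether an amine or a carboxylic acid on this aromatic ring would move the number further. From the compounds shown here alone, all four compounds share one core, so the effect of changes to that core also stays open.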